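The compounds below may be only part of what the source reports. "The series", "measured", "known", "first", "only" and "open" are said of these compounds alone.

Measured compounds:
compound 1 `COc1cc(-n2cc(-c3ccc(N)cc3)nn2)cc(OC)c1OC` gives > 10000 nM
compound 2 `COc1ccc(-n2cc(-c3ccc(N)cc3)nn2)cc1O` gives > 10000 nM
compound 3 `COc1ccc(-c2cn(-c3ccc(OC)c(OC)c3)nn2)cc1OC` gives "not determined" (no result reported)

The account follows a single change made to compound 2. In a functional assay on MDA-MB-231 cells (Homo sapiens) for cytotoxicity, read by MTT assay (on this read-out lower numbers stand for stronger inhibition and higher numbers for weaker inhibition), compound 2 reaches only a limit and no number, so its reading of > 10000 nM is a limit of the assay. Among the values shown, compound 2 is not alone there: compound 1 also sits at the limit of > 10000 nM in this assay, at which 2 of the 3 values shown sit, while compound 3 carries no result at all. Nothing here therefore ranks compound 2 against any other compound; all that is known is that its inhibition in this assay did not reach a measurable level.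

Compound 4 `COc1ccc(-n2cc(-c3ccc(N)cc3)nn2)cc1OC` differs from compound 2 in one place: methyl in place of hydrogen on an oxygen on an aromatic ring. Among the compounds with values here, no pair of measured compounds shows the effect of this change, so the size of the step can only be expected, not read off. Given that compound 1, which bears methoxy groups on the same side of the core, also sits at a limit of > 10000 nM, no movement beyond the usual scatter is expected, and compound 4 is expected to remain at a limit as well. The step from compound 2 to compound 4 is estimated at a step that the limit leaves unreadable from compound 2 to compound 4. In this assay compound 4 is thus expected to give about 20000 nM, within a range from 6000 nM to 80000 nM.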

Compound 4, half-maximal inhibitory concentration: > 10000 nM
Compound 4: only a limit was reported; the forecaster's own chance of this, stated with the estimate: 80%; the middle value is on the limit's open side.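

Compound 4 also reaches only a limit in this assay, and no step can be read from compound 2 to compound 4 or from compound 1 to compound 4. The compounds shown leave open whether hydroxy to methoxy changes inhibition at all, and how these compounds would rank against one another: the limit of > 10000 nM in this assay, at which 3 of the 4 values shown sit.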